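A few compounds are considered here, and "the series" means these few. Any claim that something is new, unique, unknown or untested is made for them only; others in the source may bear on it.

Working notes on the series.

Three members have been measured and one has not. Compound 1 `CC1=CCC[C@](C)(CC/C(C)=C/CC2=C(O)C(=O)C=C(N[C@H](C(=O)O)[C@@H](C)O)C2=O)[C@@H]1C`, compound 2 `C=C1[C@H](C)CCC[C@]1(C)CC/C(C)=C/CC1=C(O)C(=O)C=C(N[C@H](CO)C(=O)O)C1=O` and compound 3 `CC1=CCC[C@](C)(CC/C(C)=C/CC2=C(O)C(=O)C=C(N[C@@H](CO)C(=O)O)C2=O)[C@@H]1C` carry the same amino-acid-bearing quinone arrangement on differing terpene cores. Compound 4 `C=C1[C@H](C)CCC[C@]1(C)CC/C(C)=C/CC1=C(O)C(=O)C=C(N[C@@H](C(=O)O)[C@@H](C)O)C1=O` remains to be measured.

In an ADME assay on KB cells (Homo sapiens) for cytotoxicity, with a stated time of 48 h (a lower number here means a stronger inhibitor, a higher number a weaker inhibitor), compound 1 gives > 10 ug/mL, which is a limit of the assay and not a number. In this assay compound 2 gives > 10 ug/mL, likewise a limit. In this assay compound 3 gives > 10 ug/mL, again a limit. Going by the values given here, the position of the whole set is summarised by the limit of > 10 ug/mL in this assay, at which 3 of the 3 values shown sit; no step among the three can be sized from such values.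

The change from compound 3 to compound 1 is methyl in place of hydrogen on a saturated chain carbon bound to an oxygen on a saturated carbon and a saturated chain carbon, and the step it made in this assay is a step that the two limits leave unreadable from compound 3 to compound 1. The same change is applied from compound 2 to compound 4, (methyl in place of hydrogen on a saturated chain carbon bound to an oxygen on a saturated carbon and a saturated chain carbon), on the other core; it occurs twice in the set. How the cores of compound 2 and compound 3 differ is not broken down here.

For compound 4 the expected step in this assay is a step that the limit leaves unreadable from compound 2 to compound 4, and this expectation rests on the fact that, because the limit of > 10 ug/mL in this assay, at which 3 of the 3 values shown sit, places every measured value at the limit, a methyl added where it left compound 1 at the limit is not expected to move compound 4 off it. Compound 4 is therefore estimated at 20 ug/mL, with a range from 10 ug/mL to 60 ug/mL.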

Compound 4, half-maximal inhibitory concentration: > 10 ug/mL
Compound 4: a limit, no number (the forecaster's own chance of this, stated with the estimate: 85%); the middle value lies beyond the limit too.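

In this assay compound 4 gives > 10 ug/mL, a limit and not a number, so no step can be read between compound 2 and compound 4. The whole set stands at one limit: the limit of > 10 ug/mL in this assay, at which 4 of the 4 values shown sit. The compounds shown leave open how the two cores, or the change from hydroxymethyl to 1-hydroxyethyl, bear on this assay, where none of them gives a number.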